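This account rests on a few compounds, and the source may have more. Where it says the series, first, only, none or still open, it means among the compounds named here.

In a functional assay on DU-145 cells (Homo sapiens) for antiproliferative activity, read by propidium iodide staining, with a stated time of 96 h (on this read-out higher numbers stand for weaker inhibition and lower numbers for stronger inhibition), compound 1 `CC(O)(CSc1cccc(S(F)(F)(F)(F)F)c1)C(=O)Nc1ccc([N+](=O)[O-])cc1C(F)(F)F` gives 18900 nM, compound 2 `CC(O)(CSc1ccc(S(F)(F)(F)(F)F)cc1)C(=O)Nc1ccc(S(F)(F)(F)(F)F)cc1` gives 22300 nM, and compound 3 `CC(O)(CSc1ccc(S(F)(F)(F)(F)F)cc1)C(=O)Nc1cccc(S(F)(F)(F)(F)F)c1` gives 24800 nM. The number for compound 3 lies within the usual scatter of both other values, so these measurements do not separate the three compounds.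

The next compound, compound 4 `CC(O)(CSc1ccc(F)cc1)C(=O)Nc1cccc(S(F)(F)(F)(F)F)c1`, differs from compound 3 in one place: one fluorine atom in place of a group of 6 heavy atoms (5 fluorine, 1 sulfur; no ring), on an aromatic carbon. In words, one fluorine atom stands in place of a group of 6 heavy atoms (5 fluorine, 1 sulfur; no ring), on an aromatic carbon, para to a large group.

Among the measured compounds shown here, no two measured compounds differ in one place alone, so the data give no direct guide to this swap. The only hint is how closely the three values sit, so no shift beyond the scatter is expected in this assay, and no direction can be favoured. The expected step is small: a 1.0-fold higher number from compound 3 to compound 4 (0.00 log units; within the scatter). The estimate for compound 4 is 25000 nM, with an expected range of 10000 nM to 60000 nM.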

Compound 4, half-maximal inhibitory concentration: 38500 nM
Estimate against measurement, compound 4: 1.5-fold (0.19 log units) below; the range from low to high includes it.
By their numbers in this assay, from the lowest: compounds 1, 2, 3 and 4 (each within the scatter of the next, the first and the last beyond it).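

In this assay, among the compounds shown here, this is the first comparison in the set where two compounds differ in one place alone: the step of a 1.6-fold higher number from compound 3 to compound 4 (0.19 log units; within the scatter) comes from putting one fluorine atom in place of the group of 6 heavy atoms (5 fluorine, 1 sulfur), para to a large group. A much smaller group on this aromatic carbon therefore gives no shift that can be told apart from the scatter, a finding that rests on this single pair. No measurement bears on why the two numbers sit so close.

Going by these compounds, it remains open whether an amine, a carboxylic acid or a plain hydrogen on this carbon would move the number beyond the scatter. On these data alone, the same swap at other places on the shared core also remains untested by these compounds.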